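Swapping a Ketone for an Alkene on the Pyrazolone Core

This account rests on a few compounds, and the source may have more. Where it says the series, first, only, none or still open, it means among the compounds named here.

Of the compounds shown here, three with a shared core have been measured in a functional assay on the whole organism (Abdomen, strain Swiss) for inhibition, with Mus musculus as the target, with stated times of 30 min, 10 min and 5 min, at a dose of 40 mg/kg by the oral route; a higher number here means a stronger effect of the compound at the dose given, a lower number a weaker effect. Compound 1 `CCCCC(=O)c1c(C)nn(CCCN2CCN(c3ccc(C)cc3)CC2)c(=O)c1N` gives 15%, compound 2 `C=Cc1c(CC)nn(CCCN2CCN(c3ccc(C)cc3)CC2)c(=O)c1N` gives 28%, and compound 3 `C=Cc1c(CCCC)nn(CCCN2CCN(c3ccc(C)cc3)CC2)c(=O)c1N` gives 48%. Compound 1 thus stands lowest of the three, beyond the scatter below both of the others, with compound 2 the nearer and compound 3 the further.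

Among the compounds with values here, the only single-point step among the measured compounds is a number 20 percentage points higher from compound 2 to compound 3 (beyond the scatter), a lengthening of the saturated chain that accompanies a modest rise. Within the data shown here, no measured pair shows directly what happens at the place that changes in compound 4 `CCC/C=C/c1c(C)nn(CCCN2CCN(c3ccc(C)cc3)CC2)c(=O)c1N`, which differs from compound 1 by pent-1-en-1-yl in place of butylcarbonyl on an aromatic carbon: the butylcarbonyl, with its one hydrogen-bond acceptor, leaves and a pent-1-en-1-yl with none enters. What compounds 2 and 3 do show is that an alkene rather than a carbonyl on that core goes together with higher numbers than compound 1, so an upward step is expected, though compound 4 keeps the methyl of compound 1 rather than the longer chains of compounds 2 and 3, which tempers the expectation. Compound 4 is therefore expected to give about 30%, within 12% to 50%, a rise of a number 15 percentage points higher from compound 1 to compound 4 (beyond the scatter).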

Compound 4, a percentage reported as inhibition, in the whole organism at one dose (the size of the read-out at that dose, not a potency): 36%
For compound 4 the middle estimate is 6 percentage points below the measured one; measured number inside the range.
By their numbers in this assay, from the lowest: compound 1; then compounds 2 and 4 (each within the scatter of the next); then compound 3.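

In this assay, within the data shown here, exchanging butylcarbonyl for pent-1-en-1-yl on the aromatic carbon opposite the ring nitrogen gives a number 21 percentage points higher from compound 1 to compound 4 (beyond the scatter), the first direct reading at this position, as the earlier step concerned only a saturated chain elsewhere on the shared core. The two groups match in their counts of 5 carbon atoms and 1 double bond outside aromatic rings, and they differ in that the butylcarbonyl carries 1 oxygen and 1 hydrogen-bond acceptor, whereas the pent-1-en-1-yl carries neither, so this step ties the higher number to that exchange as a whole, with the rest of compound 1 unchanged. No measurement at hand accounts for the rise.

The compounds shown leave open whether the rise depends on the double bond of the pent-1-en-1-yl or simply on the loss of the carbonyl, a question that a saturated pentyl chain at this position would address. They also leave open how an ether, a hydroxyl or an amine on the chain at this place would fare, and whether a shorter or longer chain would keep the step.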